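A few compounds are considered here, and "the series" means these few. Any claim that something is new, unique, unknown or untested is made for them only; others in the source may bear on it.

The study looks at aryloxy nitriles in an assay on isolated protein for inhibition of leukotriene B4 receptor 1 (Homo sapiens), tested at 10 uM; a higher number here means more inhibition at the concentration tested (going by the name of the read-out), a lower number less inhibition. Compound 1 `CC(=O)c1ccc(OCCCCC#N)cc1O` gives 0% in this assay. Compound 2 `CC(=O)c1cc(CO)c(OCCCCCCC#N)cc1O` gives 40% in this assay. Compound 3 `C=CCc1cc(C(C)=O)c(O)cc1OCC#N` gives 20% in this assay, which places it second highest of the three numbers: it lies above compound 1 by a gap beyond the scatter and below compound 2 by a gap beyond the scatter, the nearest neighbour on the numbers being compound 1.

The next compound is compound 4 `C=CCc1cc(C(C)=O)c(O)cc1OCCCC#N`. It differs from compound 3 in one place: 2-cyanoethyl in place of cyano on a saturated chain carbon bound to an oxygen on an aromatic ring. Compound 3 and compound 4 thus share the same core, and only the length of the chain between the aromatic oxygen and the nitrile changes.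

Among the measured compounds shown here, no step between two measured compounds that differ in a single place is available, so the expectation rests on the values alone. Compound 2, which carries the longer chain, shows a higher number than compound 1, which carries the shorter one, though the two differ in other places as well. A small rise in inhibition is therefore expected for the step of a number 10 percentage points higher from compound 3 to compound 4 (within the scatter) in this assay, at the edge of the scatter. Compound 4 is estimated at 30%, with a range from 10% to 50%.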

Compound 4, a percentage reported as inhibition, at one concentration (the size of the read-out at that concentration, not a potency): 47%
Compound 4: middle estimate off by 17 percentage points, on the low side; measured number inside the range.
By their numbers in this assay, from the lowest: compound 1; then compound 3; then compounds 2 and 4 (each within the scatter of the next).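

In this assay, among the compounds shown here, putting 2-cyanoethyl in place of cyano on a saturated chain carbon bound to an oxygen on an aromatic ring gives a number 27 percentage points higher from compound 3 to compound 4 (beyond the scatter) and is the only comparison here in which a single place changes. It shows that this position responds to the length of the chain carrying the nitrile: with the shared core held fixed, going from cyanomethoxy to 3-cyanopropoxy moves the inhibition at the concentration tested by more than the scatter, which compounds 1 and 2, differing from the others in several places at once, could not show on their own. Nothing available here accounts for the rise.

With one step on one core, the compounds shown cannot tell whether a longer chain would carry the rise further or whether the trend would hold on the cores of compound 1 and compound 2. On these data alone, it also remains open whether the nitrile itself is needed at the end of the chain, or whether a carboxylic acid or an amine in its place would keep the inhibition seen with compound 4.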